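Chain extension on the ring nitrogen: compound 2 to compound 3

The source may report more compounds than this note shows. Statements on the series, on what has been measured and on what is new or still open speak of the compounds shown alone.

The series keeps one shared core and varies what hangs on its ring nitrogen. Compound 1 `CC1(C)C2CC[C@]1(C)CN(C1CCCCC1)C2` carries a cyclohexyl directly on that nitrogen; compound 2 `CC1(C)C2CC[C@]1(C)CN(CCCC1CCCCC1)C2` carries the cyclohexyl at the end of a saturated chain from the nitrogen. In an assay on isolated protein (Cavia porcellus) for binding affinity to Sigma non-opioid intracellular receptor 1 (Homo sapiens) (a lower number here means a stronger inhibitor, a higher number a weaker inhibitor), compound 1 gives 3 nM and compound 2 gives 2.53 nM. Compound 2 stands at the lower of the two numbers, but its gap to compound 1 is within the scatter, so the two read as equivalent. Compound 3 `CC1(C)C2CC[C@]1(C)CN(CCCCC1CCCCC1)C2` differs from compound 2 in one place: cyclohexylmethyl in place of cyclohexyl on a saturated chain carbon, three bonds along the chain from an amine nitrogen in a ring. For the measured compounds named here, no step between measured compounds isolates such a chain extension, and the pair in hand shows no sensitivity to how far the cyclohexyl sits from the nitrogen, compound 1 and compound 2 being indistinguishable. The expected step from compound 2 to compound 3 in this assay is therefore a 1.2-fold higher number from compound 2 to compound 3 (0.07 log units; within the scatter), nothing beyond the scatter in either direction. Compound 3 is estimated to give about 3 nM in this assay, within 1 nM to 10 nM.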

Compound 3, inhibition constant: 1.2 nM
The estimate for compound 3 lay 2.5-fold (0.40 log units) above the measured number; measured number inside the range.
By their numbers in this assay, from the lowest: compound 3; then compounds 2 and 1 (each within the scatter of the next).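

In this assay, cyclohexylmethyl in place of cyclohexyl on a saturated chain carbon, three bonds along the chain from an amine nitrogen in a ring, gives a 2.1-fold lower number from compound 2 to compound 3 (0.32 log units; beyond the scatter) and thereby shows that this position responds to the change. For the compounds shown here, the step is modest, but it is the one measured change here that isolates this chain extension, and it shows that the extended chain is tolerated and goes with a lower number in this assay, not a higher one. No measurement in hand bears on why the number falls with this change.

As far as these compounds go, a single step fixes no trend, so it remains open whether a longer chain ending in cyclohexyl would keep the number falling, hold it level or reverse the direction. From the compounds shown here alone, it also remains open whether the step depends on the saturated carbocycle itself, which phenyl or piperidine in place of the cyclohexyl ring of compound 3 would test, or whether an ether oxygen or an amide within the chain would be tolerated at this place.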